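Halogen swap across two cores, cytotoxicity notes

The source may hold more compounds than are shown below. What is called first, only, known or untested is meant among the compounds shown, and "the series" means these compounds.

Compound 1 `C=C[C@@](C)(/C=C/c1ccc(O)c(/C=C/c2ccc(F)cc2)c1)CCC=C(C)C` and compound 2 `C=C[C@@](C)(/C=C/c1ccc(O)c(/C=C/c2ccc(Cl)cc2)c1)CCC=C(C)C` share one core; compound 3 `CC(C)=CCC[C@](C)(/C=C/c1ccc(O)cc1)/C=C/c1cccc(F)c1` and compound 4 `CC(C)=CCC[C@](C)(/C=C/c1ccc(O)cc1)/C=C/c1cccc(Cl)c1` share another, and the difference between the two cores is not broken down here. In a functional assay on NALM-6 cells (Homo sapiens) for cytotoxicity, with a stated time of 72 h (on this read-out higher numbers stand for an effect only at larger amounts of compound and lower numbers for an effect already at smaller amounts), compound 1 gives only a limit, > 43400 nM. Compound 2 likewise gives only a limit in this assay, > 43400 nM. The change from the first to the second is chloro in place of fluoro on an aromatic carbon, and the result is a step that the two limits leave unreadable from compound 1 to compound 2. Compound 3 also gives only a limit in this assay, > 43400 nM. Among the measured compounds shown here, compound 4 is not yet measured; it differs from compound 3 by chloro in place of fluoro on an aromatic carbon, the same kind of change as the one within the first pair, the place here being meta to a large group where there it was para to a large group. What the measured values show is the limit of > 43400 nM in this assay, at which 3 of the 3 values shown sit. The step from compound 3 to compound 4 in this assay is expected to be a step that the limit leaves unreadable from compound 3 to compound 4. This expectation rests on compound 3, whose value is a limit, > 43400 nM. For compound 4 the estimated value in this assay is 60000 nM, expected between 30000 nM and 200000 nM, most likely again reported only as a limit.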

Compound 4, half-maximal effective concentration: > 43400 nM
Compound 4 was reported as a limit; the forecaster's own chance of this, stated with the estimate: 85%; the middle value is on the limit's open side.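

No new step can be read: compound 3 and compound 4 both end as limits in this assay, so the change from 3-fluorophenyl to 3-chlorophenyl has no readable size: the limit of > 43400 nM in this assay, at which 4 of the 4 values shown sit.

The compounds shown leave open whether any of them reaches a measurable half-maximal effective concentration in this assay, and how chloro and fluoro compare on either core.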